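The source may hold more compounds than are shown below. What is called first, only, known or untested is meant among the compounds shown, and "the series" means these compounds.

Compound 1 `Nc1nc(-c2ccccn2)nn1-c1ncnc2ccccc12` stands at the weak end in an assay on MCF7 cells for inhibition of Serine-protein kinase ATM (Homo sapiens), read by immunofluorescence, with a stated time of 1 h (on this read-out lower numbers stand for stronger inhibition and higher numbers for weaker inhibition), where compound 1 gives only a limit of the assay, > 40000 nM. Compound 2 `COc1ccc(-c2nc(N)n(-c3ncnc4ccccc34)n2)cc1` differs from it by 4-methoxyphenyl in place of pyridin-2-yl on an aromatic carbon; in this assay compound 2 likewise gives a limit, > 40000 nM. The step that the two limits leave unreadable from compound 1 to compound 2 therefore cannot be read, because both values sit at the limit of > 40000 nM in this assay, at which 2 of the 2 values shown sit. Compound 3 `Nc1nc(-c2ccccn2)nn1-c1ncnc2cc(OC(F)(F)F)ccc12` differs from compound 1 by trifluoromethoxy in place of hydrogen on an aromatic carbon, a change on the shared core rather than on the pendant ring. Among the measured compounds shown here, no measured step touches this part of the structure, and the one measured step is unreadable, so nothing here points in either direction. Compound 1 stands at a limit, and compound 3 is expected to stay near it: the estimated step of a number no higher from compound 1 to compound 3 (the limit leaves the size open) is taken as none beyond the scatter. Compound 3 is accordingly estimated at 40000 nM, between 10000 nM and 100000 nM, with a high chance that the assay again reports only a limit.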

Compound 3, half-maximal inhibitory concentration: > 40000 nM
Compound 3 ended at the assay's limit; the forecaster's own chance of this, stated with the estimate: 75%; the middle value lies on the limit itself.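

Compound 3 adds no readable step: its comparison with compound 1 cannot be read, because compound 1, compound 2 and compound 3 all stand at the same limit: the limit of > 40000 nM in this assay, at which 3 of the 3 values shown sit.

The compounds shown leave open how strongly any of them inhibits in this assay, and whether either change has any effect there.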